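Notes on the step from compound 1 to compound 3

The source may report more compounds than this note shows. Statements on the series, on what has been measured and on what is new or still open speak of the compounds shown alone.

Measured so far:
compound 1 `CCN1C/C(=C\c2ccc(OC)c(OC)c2)C(=O)/C(=C/c2ccc(OC)c(OC)c2)C1` — 9800 nM
compound 2 `COc1cc(/C=C2\CNC/C(=C\c3cc(OC)c(OC)c(OC)c3)C2=O)cc(OC)c1OC` — 7600 nM

All numbers come from an ADME assay on L02 cells (Homo sapiens) for cytotoxicity, read by MTT assay, with a stated time of 72 h; on this read-out lower numbers stand for stronger inhibition and higher numbers for weaker inhibition. Compound 1 holds the highest of the two numbers, and compound 2 lies within the usual scatter of it, so the two show no order. Compound 3 `COc1ccc(/C=C2\CN(C)C/C(=C\c3ccc(OC)c(OC)c3)C2=O)cc1OC` awaits measurement. It differs from compound 1 by hydrogen in place of methyl on a saturated chain carbon bound to an amine nitrogen in a ring. Within the data shown here, no measured pair isolates this change, so nothing in hand speaks for a shift; the step of a 1.1-fold lower number from compound 1 to compound 3 (0.04 log units; within the scatter) is expected to stay within the scatter. For compound 3 the estimate is 9000 nM, with a range of 4500 nM to 18000 nM.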

Compound 3, half-maximal inhibitory concentration: 18200 nM
Beside the measured number, compound 3's estimate is 2.0-fold (0.31 log units) below it, and the stated range ends below it.
By their numbers in this assay, from the lowest: compounds 2, 1 and 3 (each within the scatter of the next, the first and the last beyond it).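

In this assay the pair gives a 1.9-fold higher number from compound 1 to compound 3 (0.27 log units; within the scatter) for hydrogen in place of methyl on a saturated chain carbon bound to an amine nitrogen in a ring, the same difference as ethyl to methyl. Among these compounds, this is the first direct reading at this position, and ethyl and methyl are not separated here on this read-out. No evidence bearing on this pair is at hand. Still open, going by these compounds, is whether a longer chain, or a chain ending in a carboxylic acid or an amine, would move the number beyond the scatter.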